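The source may hold more compounds than are shown below. What is called first, only, known or untested is meant among the compounds shown, and "the series" means these compounds.

Measured compounds:
compound 1 `O=[N+]([O-])c1cccc(CSc2nnc(-c3ccc4c(c3)OCCO4)n2-c2ccccc2)c1`: 30100 nM
compound 2 `Fc1ccccc1CSc1nnc(-c2ccc3c(c2)OCCO3)n1-c1ccccc1`: 18600 nM
compound 3 `Fc1ccc(CSc2nnc(-c3ccc4c(c3)OCCO4)n2-c2ccccc2)cc1`: > 100000 nM

In a functional assay on BGC-823 cells (Homo sapiens) for antiproliferative activity, read by MTT assay, with a stated time of 24 h (a lower number here means a stronger inhibitor, a higher number a weaker inhibitor), compound 1 gives 30100 nM, the highest of the two plain numbers; compound 2 sits nearest, with a 1.6-fold lower number from compound 1 to compound 2 (0.21 log units; within the scatter). For compound 3 the assay reports only a limit, > 100000 nM; the limit of > 100000 nM in this assay, at which 1 of the 3 values shown sits, marks where it sits.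

Compound 4 `Fc1ccc(CSc2nnc(-c3ccc4c(c3)OCCO4)n2-c2ccccc2)c(F)c1` is not yet measured. It differs from compound 1 by 2,4-difluorophenyl in place of 3-nitrophenyl on a saturated chain carbon bound to a sulfur. For the measured compounds named here, two measured steps bear on this: the step to the 2-fluorophenyl analogue, a 1.6-fold lower number from compound 1 to compound 2 (0.21 log units; within the scatter), which lies within the scatter, and the step to the 4-fluorophenyl analogue, an at least 3.3-fold higher number from compound 1 to compound 3 (0.52 log units; beyond the scatter), which is beyond it and ends at a limit. The 2,4-difluorophenyl group carries both substitutions, so the step in this assay from compound 1 to compound 4 is expected to go toward a higher number, with a real chance that only a limit is reported.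

The estimate for compound 4 is 60000 nM, range 20000 nM to 180000 nM, meaning an expected step of a 2.0-fold higher number from compound 1 to compound 4 (0.30 log units; within the scatter).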

Compound 4, half-maximal inhibitory concentration: > 100000 nM
Compound 4 was reported as a limit; the forecaster's own chance of this, stated with the estimate: 45%; at least 1.6-fold (0.22 log units) between middle value and limit.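

In this assay, adding a fluoro to the 2-fluorophenyl group does not keep a measurable number, with an at least 5.3-fold higher number from compound 2 to compound 4 (0.73 log units; beyond the scatter). Replacing the 3-nitrophenyl group gives an at least 3.3-fold higher number from compound 1 to compound 4 (0.52 log units; beyond the scatter), so both groups shown with the 4-fluoro substitution, in compound 3 and compound 4, end at a limit, and no compound shown goes against this. Compound 4 is reported only as a limit, as is compound 3, so the step between them cannot be read: the limit of > 100000 nM in this assay, at which 2 of the 4 values shown sit.

Going by these compounds, how far compound 3 and compound 4 lie past the limit remains unknown, so any contribution of the second fluoro to the 4-fluorophenyl group cannot be told. Also open, on these data alone, is whether a 4-chlorophenyl or 4-methoxyphenyl group on a saturated chain carbon bound to a sulfur would end at the same limit.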